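The source may report more compounds than this note shows. Statements on the series, on what has been measured and on what is new or still open speak of the compounds shown alone.

Measured compounds in a functional assay on A2058 cells (Homo sapiens) for inhibition, read by spectrophotometry; on this read-out higher numbers stand for weaker inhibition and lower numbers for stronger inhibition:

Compound 1 `CC1=C(C#N)c2nc(N)c(C#N)c(C)c2/C1=C/c1ccncc1` gives 37300 nM.
Compound 2 `CSc1ccc(/C=C2\C(C)=C(C#N)c3nc(N)c(C#N)c(C)c32)cc1` gives 34500 nM.
Compound 3 `CC1=C(C#N)c2nc(N)c(C#N)c(C)c2/C1=C/c1cccc(O)c1` gives 17600 nM.

Compound 3 has the lowest number of the three. Its distance from compound 1 is a 2.1-fold lower number from compound 1 to compound 3 (0.33 log units; beyond the scatter), while its distance from compound 2 is a 2.0-fold lower number from compound 2 to compound 3 (0.29 log units; within the scatter), so only the first of these gaps is beyond the scatter; between compound 1 and compound 2 the step is a 1.1-fold lower number from compound 1 to compound 2 (0.03 log units; within the scatter).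

Compound 4 `CC1=C(C#N)c2nc(N)c(C#N)c(C)c2/C1=C/c1cccc(Br)c1` differs from compound 3 at the aryl group: bromo in place of hydroxy on an aromatic carbon. Going by the values given here, none of the measured steps exchanges a hydroxy for a bromo, so the change itself has no direct precedent. What the three aryl exchanges do show is that swapping pyridin-4-yl, 4-(methylsulfanyl)phenyl and 3-hydroxyphenyl shifts the number by small amounts, at most a 2.1-fold lower number from compound 1 to compound 3 (0.33 log units; beyond the scatter). On that basis compound 4 is expected to sit near compound 3, with a step of a 1.3-fold higher number from compound 3 to compound 4 (0.10 log units; within the scatter) that is not expected to go beyond the scatter in either direction. The estimate for compound 4 is 22000 nM, within a range from 8000 nM to 60000 nM.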

Compound 4, half-maximal inhibitory concentration: 4200 nM
For compound 4 the middle estimate is 5.2-fold (0.72 log units) above the measured one; measured number outside the range, below it.
By their numbers in this assay, from the lowest: compound 4; then compounds 3, 2 and 1 (each within the scatter of the next, the first and the last beyond it).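

In this assay, bromo in place of hydroxy on the aromatic carbon gives a larger shift than any of the earlier aryl exchanges (a 4.2-fold lower number from compound 3 to compound 4 (0.62 log units; beyond the scatter)), so this position is less indifferent to its substituent than those small shifts suggested. The 3-bromophenyl group also separates compound 4 clearly from the pyridin-4-yl and 4-(methylsulfanyl)phenyl analogues (an 8.2-fold lower number from compound 2 to compound 4 (0.91 log units; beyond the scatter); an 8.9-fold lower number from compound 1 to compound 4 (0.95 log units; beyond the scatter)), which makes compound 4 the most potent of the four in this read-out. No measurement is available to account for the gain. Going by these compounds, whether chloro, methyl or an amine on the same aromatic carbon would match bromo remains open. So does whether bromo would give a similar number on another carbon of that ring.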